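From Dimethylamide to Ethylamide in a Paw Edema Series

The source may report more compounds than this note shows. Statements on the series, on what has been measured and on what is new or still open speak of the compounds shown alone.

compound 1 `COc1cc2c(cc1OC)C(CC(=O)O)CC2`: 18.8%
compound 2 `CNC(=O)CC1CCc2cc(OC)c(OC)cc21`: 15.6%
compound 3 `COc1cc2c(cc1OC)C(CC(=O)N(C)C)CC2`: 25%

Of the compounds shown here, three sharing one core have been tested in a functional assay on the whole organism (strain Wistar) for inhibition, with Rattus norvegicus as the target, read by paw edema, with stated times of 60 min and 1 h, at a dose of 100 mg/kg by the oral route; a lower number here means less inhibition, a higher number more inhibition at the dose given (going by the name of the read-out). Compound 3 gives the highest of the three numbers, yet the steps reaching it, a number 6.2 percentage points higher from compound 1 to compound 3 (within the scatter) and a number 9.4 percentage points higher from compound 2 to compound 3 (within the scatter), both lie within the scatter, as does a number 3.2 percentage points lower from compound 1 to compound 2 (within the scatter); on these numbers the three compounds cannot be told apart.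

The next compound, compound 4 `CCNC(=O)CC1CCc2cc(OC)c(OC)cc21`, is related to compound 3 by ethylamino in place of dimethylamino on a carbonyl carbon. Among the measured compounds shown here, the step that bears on it most directly is the one from compound 2 to compound 3, where methyl in place of hydrogen on an amide-type nitrogen gave a number 9.4 percentage points higher from compound 2 to compound 3 (within the scatter); compound 4 reverses that direction by bringing back a hydrogen-bond donor on the nitrogen, while the step from compound 1 to compound 2 shows that a secondary amide and the acid sit close together. Since all steps seen are within the scatter, the expectation for compound 4 is a step of a number 6 percentage points lower from compound 3 to compound 4 (within the scatter), not beyond the scatter. Compound 4 is therefore estimated to give 19% in this assay , within 8% to 31%.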

Compound 4, a percentage reported as inhibition, in the whole organism at one dose (the size of the read-out at that dose, not a potency): 15.6%
Beside the measured number, compound 4's estimate is 3.4 percentage points above it; low and high end bracket the measured number.
By their numbers in this assay, from the lowest: compounds 2, 4, 1 and 3 (each within the scatter of the next).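

In this assay, ethylamino in place of dimethylamino on a carbonyl carbon gives a number 9.4 percentage points lower from compound 3 to compound 4 (within the scatter) even though the two groups hold the same heavy atoms and only ethylamino carries a hydrogen-bond donor, so this rearrangement at the position does not produce a step that can be told from the scatter. Methyl in place of hydrogen on the saturated chain carbon bound to the amide-type nitrogen gives no change at the digits printed from compound 2 to compound 4 (within the scatter) and ethylamino in place of hydroxy on the carbonyl carbon gives a number 3.2 percentage points lower from compound 1 to compound 4 (within the scatter), which shows that neither extending methylamino to ethylamino nor replacing the hydroxy with ethylamino separates compound 4 from its neighbours. No measurement available here offers an explanation for any of these numbers.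

All four compounds stand within the scatter of one another, so no group at this position has yet set a compound apart. As far as these compounds go, it remains open whether a longer chain on the amide-type nitrogen, such as butylamino, or a cyclic amine on the carbonyl carbon, such as morpholine or piperidine, would give a step beyond the scatter.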